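Swapping the phenol ring of compound 1 for pyridine

The source may hold more compounds than are shown below. What is called first, only, known or untested is meant among the compounds shown, and "the series" means these compounds.

In a functional assay on HepG2 cells (Homo sapiens) for cytotoxicity, read by spectrophotometry, with a stated time of 72 h (a higher number here means a weaker inhibitor, a lower number a stronger inhibitor), compound 1 `COc1ccc(-c2cccc(=O)n2-c2cc(OC)c(OC)c(OC)c2)cc1O` gives < 10 nM, which is a limit and not a number. Compound 2 `COc1cc(-n2c(-c3ccc([N+](=O)[O-])cc3)cccc2=O)cc(OC)c1OC` likewise gives only a limit, < 10 nM. Compound 3 `COc1cc(-n2c(-c3cccc(F)c3)cccc2=O)cc(OC)c1OC` gives 159 nM. Compound 4 `COc1cc(-n2c(-c3ccncc3)cccc2=O)cc(OC)c1OC` has pyridin-4-yl in place of 3-hydroxy-4-methoxyphenyl on an aromatic carbon. Three measured exchanges at this same place bear on it: a step that the two limits leave unreadable from compound 1 to compound 2, an at least 15-fold higher number from compound 1 to compound 3 (1.20 log units; beyond the scatter) and an at least 15-fold higher number from compound 2 to compound 3 (1.20 log units; beyond the scatter). The exchanges therefore range from unreadable to large, and a moderate rise towards a weaker inhibitor is expected in this assay. The expected change is an at least 4.0-fold higher number from compound 1 to compound 4 (0.60 log units; beyond the scatter). For compound 4 the estimate is 40 nM, with an expected range from 6 nM to 250 nM.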

Compound 4, half-maximal inhibitory concentration: 1780 nM
Beside the measured number, compound 4's estimate is 45-fold (1.65 log units) below it, and the stated range ends below it.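

In this assay, pyridin-4-yl at this place gives an at least 170-fold higher number from compound 1 to compound 4 (2.25 log units; beyond the scatter) and an at least 170-fold higher number from compound 2 to compound 4 (2.25 log units; beyond the scatter), so this position tolerates less than the earlier compounds had shown. Even against the 3-fluorophenyl group, the exchange gives an 11-fold higher number from compound 3 to compound 4 (1.05 log units; beyond the scatter), which leaves compound 4 the weakest of the four. The two largest steps start from a limit, so they give only a lower bound on the change: the limit of < 10 nM in this assay, at which 2 of the 4 values shown sit.

On these data alone, whether plain phenyl or a phenyl ring carrying an amine would fall nearer compound 3 or compound 4 stays open. The compounds shown also do not separate the entering ring nitrogen from the departing hydroxy and methoxy groups.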